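Replacing the hydroxy of compound 3 with (4-methylpiperazin-1-yl)methyl

This account rests on a few compounds, and the source may have more. Where it says the series, first, only, none or still open, it means among the compounds named here.

Measured in an ADME assay on HEK293 cells (Homo sapiens) for cytotoxicity, read by MTT assay, with a stated time of 48 h; a lower number here means a stronger inhibitor, a higher number a weaker inhibitor:
- compound 1 `CCn1c(N)c(-c2nc3ccccc3[nH]2)c2nc(C#N)c(C#N)nc21` gives > 50000 nM (a limit)
- compound 2 `CCN(CC)CCn1c(N)c(-c2nc3ccccc3[nH]2)c2nc(C#N)c(C#N)nc21` gives 12200 nM (a number)
- compound 3 `N#Cc1nc2c(-c3nc4ccccc4[nH]3)c(N)n(CCO)c2nc1C#N` gives > 50000 nM (a limit)

Compound 3 stands at > 50000 nM in this assay, which is a limit and not a number. Compound 4 `CN1CCN(CCCn2c(N)c(-c3nc4ccccc4[nH]3)c3nc(C#N)c(C#N)nc32)CC1` has (4-methylpiperazin-1-yl)methyl in place of hydroxy on a saturated chain carbon, two bonds along the chain from an aromatic nitrogen. Among the compounds with values here, two measured steps bear on this change. Diethylamino in place of hydrogen gives an at least 4.0-fold lower number from compound 1 to compound 2 (0.61 log units; beyond the scatter) and hydroxy in place of diethylamino gives an at least 4.0-fold higher number from compound 2 to compound 3 (0.61 log units; beyond the scatter) as the second. The entering group differs from diethylamino, so this guide is only partial. A modest drop is expected, estimated as an at least 3.5-fold lower number from compound 3 to compound 4 (0.55 log units; beyond the scatter) in this assay overall. Compound 4 is estimated at 14000 nM with an expected range of 5000 nM to 40000 nM for the measurement.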

Compound 4, half-maximal inhibitory concentration: 6260 nM
Compound 4: middle estimate off by 2.2-fold (0.35 log units), on the high side; the range from low to high includes it.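

In this assay, the 3-(4-methylpiperazin-1-yl)propyl chain gives a measured number, with an at least 7.9-fold lower number from compound 3 to compound 4 (0.90 log units; beyond the scatter) and an at least 7.9-fold lower number from compound 1 to compound 4 (0.90 log units; beyond the scatter). Both sizes are only minimums, set by a limit of the assay: the limit of > 50000 nM in this assay, at which 2 of the 4 values shown sit. Against the diethylamino chain there is a 1.9-fold lower number from compound 2 to compound 4 (0.29 log units; within the scatter), so these two chains cannot be told apart here.

The compounds shown leave open how a morpholin-4-yl group or a carboxylic acid at the end of the chain would read in this assay. They also leave open what a longer chain carrying the same piperazine would give.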